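The compounds below may be only part of what the source reports. "The series", "measured", "known", "first", "only" and "open" are said of these compounds alone.

Measured compounds in an assay on L1210 cells for inhibition of Thymidylate synthase (Mus musculus); on this read-out higher numbers stand for weaker inhibition and lower numbers for stronger inhibition:
- compound 1 `C#CCN(Cc1cc2c(O)nc(C)nc2cc1C)c1ccc(C(=O)N[C@@H](CCC(=O)O)C(=O)N(C)[C@@H](CCC(=O)O)C(=O)O)c(F)c1`: 1.1 nM
- compound 2 `C#CCN(Cc1cc2c(O)nc(C)nc2cc1C)c1ccc(C(=O)N[C@@H](CCC(=O)O)C(=O)N(CC#C)[C@@H](CCC(=O)O)C(=O)O)c(F)c1`: 0.21 nM
- compound 3 `C#CCN(Cc1cc2c(O)nc(C)nc2cc1C)c1ccc(C(=O)N[C@@H](CCC(=O)O)C(=O)N(C)[C@@H](CCC(=O)O)C(=O)O)cc1`: 2.6 nM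

Among these three, compound 1 stands second in this assay; from compound 1 to compound 2 the step was a 5.2-fold lower number from compound 1 to compound 2 (0.72 log units; beyond the scatter), and from compound 1 to compound 3 it was a 2.4-fold higher number from compound 1 to compound 3 (0.37 log units; beyond the scatter), both modest.

Compound 4 `C#CCN(Cc1ccc2nc(C)nc(O)c2c1)c1ccc(C(=O)N[C@@H](CCC(=O)O)C(=O)N(C)[C@@H](CCC(=O)O)C(=O)O)c(F)c1` differs from compound 1 by hydrogen in place of methyl on an aromatic carbon. Neither measured step touches this part of the shared core: one changed a saturated chain carbon bound to an amide-type nitrogen, the other an aromatic carbon of a different ring. Among the compounds with values here, no measured step therefore bears directly on the change, and the direction of its effect is open. Given that both known single changes moved the number only modestly, a modest step is expected here too, and compound 4 is estimated at 3 nM (1 nM to 10 nM), a change of a 2.7-fold higher number from compound 1 to compound 4 (0.44 log units; beyond the scatter).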

Compound 4, inhibition constant: 4 nM
Estimate against measurement, compound 4: 1.3-fold (0.12 log units) below; measured number inside the range.
By their numbers in this assay, from the lowest: compound 2; then compound 1; then compounds 3 and 4 (each within the scatter of the next).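

Hydrogen in place of methyl on this aromatic carbon gives, in this assay, a 3.6-fold higher number from compound 1 to compound 4 (0.56 log units; beyond the scatter) and so shows that this methyl, on a different ring from the fluoro, goes with stronger inhibition in this one pair. The step is modest, as were the two earlier single changes, so this position also affects the number. Nothing measured here explains the step.

From the compounds shown here alone, whether an ethyl group or a methoxy group on this carbon would give a lower or higher number remains open. So does whether removing the methyl would give a similar step in compound 2 or compound 3.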